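The source may report more compounds than this note shows. Statements on the series, on what has been measured and on what is new or still open speak of the compounds shown alone.

Measured in a functional assay on NCI-H1975 cells (Homo sapiens) for antiproliferative activity, read by CellTiter-Glo, with a stated time of 96 h; a lower number here means a stronger inhibitor, a higher number a weaker inhibitor:

- Compound 1 `COc1ccc(-c2nsc3c2NC(=O)CC3c2cccc(OC)c2)cc1`: 1980 nM
- Compound 2 `COc1ccc(-c2nsc3c2NC(=O)CC3c2ccc3c(c2)OCCO3)cc1`: 1240 nM
- Compound 3 `COc1ccc(-c2nsc3c2NC(=O)CC3c2cccc(Cl)c2)cc1`: > 2000 nM, a limit of the assay and not a number

Compound 3 has no exact number, only a limit: the limit of > 2000 nM in this assay, at which 1 of the 3 values shown sits. Its true potency therefore cannot be read from these data.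

The next compound is compound 4 `COc1ccc(-c2nsc3c2NC(=O)CC3c2cccc(F)c2)cc1`, which has not yet been measured. The change is small: fluoro in place of chloro on an aromatic carbon. In words, fluoro takes the place of chloro on an aromatic carbon, so 3-chlorophenyl becomes 3-fluorophenyl.

Within the data shown here, no measured step makes this exact swap. The nearest one changes the same place on the ring, with chloro in place of methoxy: a number no lower from compound 1 to compound 3 (the limit leaves the size open). Its size cannot be read, so it gives only a loose guide and no firm direction for the new change. The best anchor is compound 1 at 1980 nM, which carries a different group at that place and still gives a measurable value.

A small step at most, with no clear direction, is therefore expected, and compound 4 may also come back as a limit. The expected change is a number no higher from compound 3 to compound 4 (the limit leaves the size open). The estimate for compound 4 is 2000 nM. The expected range for compound 4 runs from 1000 nM to 4000 nM.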

Compound 4, half-maximal inhibitory concentration: > 2000 nM
Compound 4 gave a limit, no number (the forecaster's own chance of this, stated with the estimate: 50%); the middle value lies on the limit itself.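

Compound 4 is a limit and not a number, and so is compound 3, so fluoro in place of chloro on this ring gives no readable step: the limit of > 2000 nM in this assay, at which 2 of the 4 values shown sit.

The earlier compounds shown here showed this for chloro alone; now a second halogen at this place also gives no exact value, while compound 1, with methoxy at the same place, gives 1980 nM. Fluoro in place of methoxy gives a number no lower from compound 1 to compound 4 (the limit leaves the size open). From the compounds shown here alone, the step between the two halogens cannot be read and the size of the step from methoxy to fluoro stays open, so neither that size nor any order between chloro and fluoro can be stated.

Going by these compounds, how far the true values of compound 3 and compound 4 lie past the limit stays open. Also open, on these data alone, is how an amine or a carboxylic acid at this same place on the ring would read in this assay.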